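The compounds below may be only part of what the source reports. "The series", "measured", "known", "first", "only" and "open" are said of these compounds alone.

Values so far in a functional assay on NCI-H520 cells (Homo sapiens); a higher number here means a weaker inhibitor of growth, a lower number a stronger inhibitor of growth:
compound 1 `O=S(=O)(/C=C/c1ccc(Br)cc1)Cc1ccc(Nc2ncnc3ccccc23)cc1` > 100000 nM (a limit, not a number)
compound 2 `O=S(=O)(/C=C/c1ccc(O)cc1)Cc1ccc(Nc2ncnc3ccccc23)cc1` 100000 nM
compound 3 `O=S(=O)(/C=C/c1ccc(Br)cc1)Cc1ccc(Nc2ncnc3ccc(Br)cc23)cc1` 20000 nM

Compound 3 at 20000 nM holds the lowest number, and compound 2 stands higher at 100000 nM. Compound 4 `O=S(=O)(/C=C/c1ccc(O)cc1)Cc1ccc(Nc2ncnc3ccc(Br)cc23)cc1` carries hydroxy in place of bromo on an aromatic carbon, para to a large group (hydroxy in place of bromo on an aromatic carbon). The same exchange gave a number no higher from compound 1 to compound 2 (the limit leaves the size open), its size left open because of the limit of > 100000 nM in this assay, at which 1 of the 3 values shown sits. The added bromo gave an at least 5.0-fold lower number from compound 1 to compound 3 (0.69 log units; beyond the scatter), and compound 4 keeps that bromo. No shift beyond the scatter is therefore expected, though with wide uncertainty, and the expected step is no change at the digits printed from compound 3 to compound 4 (within the scatter). The estimate for compound 4 is 20000 nM, within 6000 nM to 70000 nM.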

Compound 4, concentration for 50% growth inhibition: 27000 nM
For compound 4 the middle estimate is 1.4-fold (0.13 log units) below the measured one; the range from low to high includes it.
By their numbers in this assay, from the lowest: compounds 3 and 4 (each within the scatter of the next); then compound 2.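

With the bromo on the shared core in place, the exchange of 4-bromophenyl for 4-hydroxyphenyl now reads as a sized step in this assay: a 1.4-fold higher number from compound 3 to compound 4 (0.13 log units; within the scatter). The added core bromo also lowers the number when hydroxy is present, with a 3.7-fold lower number from compound 2 to compound 4 (0.57 log units; beyond the scatter), so this effect no longer rests only on a pair with a limit. Whether either change differs between the two cores cannot be read: the same change on two cores in this assay, a number no higher (the limit leaves the size open) from compound 1 to compound 2 and a 1.4-fold higher number (0.13 log units; within the scatter) from compound 3 to compound 4; the limit leaves it open whether they differ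

Still open, on these data alone, is whether an amine, a methoxy or a carboxylic acid on the same aromatic carbon would stay level with bromo and hydroxy. Also open, as far as these compounds go, is whether chloro or an amine in place of the core bromo would lower the number further.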